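Third Sulfate on a Heparan Sulfate-Type Disaccharide

The source may hold more compounds than are shown below. What is called first, only, known or untested is meant among the compounds shown, and "the series" means these compounds.

Measured compounds:
compound 1 `CC(=O)N[C@H]1[C@@H](OC[C@@H](O)[C@@H](O)[C@H](O)[C@@H](O)CNc2cccc(NC(=O)CCCCC3CCSS3)c2)O[C@H](CO)[C@H](OS(=O)(=O)O)[C@@H]1O[C@@H]1O[C@H](C(=O)O)[C@@H](O)[C@H](O)[C@H]1O`, "not active" (no number reported) in an assay on isolated protein for binding affinity to fibroblast growth factor 2 (Homo sapiens), read by surface plasmon resonance; on this read-out higher numbers stand for weaker binding and lower numbers for tighter binding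
compound 2 `CC(=O)N[C@H]1[C@@H](OC[C@@H](O)[C@@H](O)[C@H](O)[C@@H](O)CNc2cccc(NC(=O)CCCCC3CCSS3)c2)O[C@H](CO)[C@H](OS(=O)(=O)O)[C@@H]1O[C@@H]1O[C@H](C(=O)O)[C@@H](O)[C@H](OS(=O)(=O)O)[C@H]1O`, 41 nM in this assay

Compound 2 is the only one of the two with a reported number in this assay; compound 1 is recorded there as "not active" (no number reported), with no number given. Compound 3 `CC(=O)N[C@H]1[C@@H](OC[C@@H](O)[C@@H](O)[C@H](O)[C@@H](O)CNc2cccc(NC(=O)CCCCC3CCSS3)c2)O[C@H](CO)[C@H](OS(=O)(=O)O)[C@@H]1O[C@@H]1O[C@H](C(=O)O)[C@@H](O)[C@H](OS(=O)(=O)O)[C@H]1OS(=O)(=O)O` differs from compound 2 by sulfo in place of hydrogen on an oxygen on a saturated carbon. Among the compounds with values here, no measured pair shows such a step. Going from compound 1 to compound 2 also added a sulfo group, so a tighter or unchanged reading is expected for compound 3, with the step of a 1.6-fold lower number from compound 2 to compound 3 (0.21 log units; within the scatter) staying within or just beyond the scatter. Compound 3 is expected to give 25 nM, ranging from 8 nM to 120 nM.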

Compound 3, dissociation constant: 52 nM
The estimate for compound 3 lay 2.1-fold (0.32 log units) below the measured number; the measured number falls inside the stated range.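

In this assay, hydroxy to sulfooxy on this oxygen gives a 1.3-fold higher number from compound 2 to compound 3 (0.10 log units; within the scatter) and so the two compounds cannot be told apart. In the earlier pair, the sulfo group that compound 2 carries and compound 1 lacks separates a measured number from a reading of "not active" (no number reported) while this further sulfo group is tolerated without a measurable difference. Nothing available explains why these two sulfo groups read so differently. As far as these compounds go, whether a methyl ether or an acetyl ester on this same oxygen would read differently remains open.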